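This account rests on a few compounds, and the source may have more. Where it says the series, first, only, none or still open, it means among the compounds named here.

Measured in a functional assay on thoracic aorta (Rattus norvegicus, strain Wistar), with a stated time of 15 min; a higher number here means that more compound is needed for the effect, a lower number that less compound is needed:
- compound 1 `CCOc1ccc(F)cc1C(C)NC(=O)N(C)S(=O)(=O)c1ccc(C)cc1`: 7800 nM
- compound 2 `CCOc1ccc(Br)cc1C(C)NC(=O)N(C)S(=O)(=O)c1ccc(C)cc1`: 28600 nM
- compound 3 `CCOc1ccc(F)cc1C(C)NC(=O)N(C)S(=O)(=O)c1ccccc1`: 11500 nM

Compound 1 sits at the low end of these numbers. Compound 4 `COc1ccc(F)cc1C(C)NC(=O)N(C)S(=O)(=O)c1ccc(C)cc1` is still unmeasured and changes ethoxy to methoxy: hydrogen in place of methyl on a saturated chain carbon bound to an oxygen on an aromatic ring. The closest parallel is the same swap made on an aromatic carbon, a 1.5-fold higher number from compound 1 to compound 3 (0.17 log units; within the scatter), which stayed within the scatter. The halogen swap, a 3.7-fold higher number from compound 1 to compound 2 (0.56 log units; beyond the scatter), went beyond it but happens elsewhere and bears less on this change. No step beyond the scatter is therefore expected in this assay, and the estimate is a 1.3-fold higher number from compound 1 to compound 4 (0.11 log units; within the scatter). For compound 4 the expected value is 10000 nM, with an estimated range of 4500 nM to 23000 nM.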

Compound 4, half-maximal effective concentration: 11700 nM
For compound 4 the middle estimate is 1.2-fold (0.07 log units) below the measured one, and the stated range covers the measured number.
By their numbers in this assay, from the lowest: compounds 1, 3 and 4 (each within the scatter of the next); then compound 2.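

Replacing ethoxy with methoxy gives a 1.5-fold higher number from compound 1 to compound 4 (0.18 log units; within the scatter) in this assay. Within the data shown here, this is the first look at the chain on the oxygen, and removing this methyl leaves the result within the scatter, as removing the methyl on the aromatic carbon did. Nothing at hand explains this result.
On these data alone, whether a longer chain such as propoxy, or a hydroxyl group in place of the ethoxy, would shift the number stays open. So does whether a larger step appears with either group.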